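This account rests on a few compounds, and the source may have more. Where it says the series, first, only, none or still open, it means among the compounds named here.

In a functional assay on CRL2813 cells (Homo sapiens) for cytotoxicity, read by sulforhodamine B assay, with a stated time of 5 days; on this read-out lower numbers stand for stronger inhibition and higher numbers for weaker inhibition:
- compound 1 `O=C(Nc1ccc(F)cc1)N[C@H]1CC[C@H](Oc2ccc(F)cc2)CC1`: 20000 nM
- compound 2 `O=C(Nc1cccc(C(F)(F)F)c1)N[C@H]1CC[C@H](Oc2cccc(C(F)(F)F)c2)CC1`: 1300 nM
- compound 3 `O=C(Nc1ccccc1F)N[C@H]1CC[C@H](Oc2ccc(F)cc2)CC1`: 17500 nM

Compound 2 has the lowest number of the three, and the values of compound 1 and compound 3 both lie beyond the scatter from it. Compound 4 `O=C(Nc1cccc(C(F)(F)F)c1)N[C@H]1CC[C@H](Oc2ccccc2C(F)(F)F)CC1` carries 2-(trifluoromethyl)phenyl in place of 3-(trifluoromethyl)phenyl on an oxygen on a saturated carbon. For the measured compounds named here, the only measured step of this kind is a 1.1-fold lower number from compound 1 to compound 3 (0.06 log units; within the scatter). It concerns a fluorophenyl on an amide-type nitrogen, so it bears on this change only indirectly. No step beyond the scatter is therefore expected in this assay. The expected step is a 1.3-fold higher number from compound 2 to compound 4 (0.12 log units; within the scatter). For compound 4 the estimate is 1700 nM, with an expected range of 650 nM to 4500 nM.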

Compound 4, half-maximal inhibitory concentration: 1400 nM
Beside the measured number, compound 4's estimate is 1.2-fold (0.08 log units) above it; low and high end bracket the measured number.
By their numbers in this assay, from the lowest: compounds 2 and 4 (each within the scatter of the next); then compounds 3 and 1 (each within the scatter of the next).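

In this assay the swap on the oxygen gives a 1.1-fold higher number from compound 2 to compound 4 (0.03 log units; within the scatter), so 2-(trifluoromethyl)phenyl and 3-(trifluoromethyl)phenyl are not told apart at this place. For the compounds shown here, the earlier compounds held no pair differing only on this oxygen; their single step concerned the amide-type nitrogen. No measurement at hand offers an explanation for this result.

Going by these compounds alone, whether the trifluoromethyl group itself matters on this phenyl stays open, as no pair sets it against another group here. A nitrile or an amine on that ring would address this.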